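Compound 2 to compound 3: one carbonyl substituent changes

The source may report more compounds than this note shows. Statements on the series, on what has been measured and on what is new or still open speak of the compounds shown alone.

Measured in a functional assay on U-87MG ATCC cells (Homo sapiens) for antiproliferative activity; on this read-out lower numbers stand for stronger inhibition and higher numbers for weaker inhibition:
Compound 1 `Cc1c2c(n3c1CCN(C)C[C@@H](C)[C@H](C)Nc1cc-3ccc1C(N)=O)CC(C)(C)CC2=O`: 49 nM
Compound 2 `COCCC(=O)N1CCc2c(C)c3c(n2-c2ccc(C(N)=O)c(c2)N[C@@H](C)[C@H](C)C1)CC(C)(C)CC3=O`: 54 nM

Compound 2 gives 54 nM, which lies within the scatter of the value for compound 1, so the two cannot be told apart on these numbers.

Compound 3 `Cc1c2c(n3c1CCN(C(=O)[C@@H](N)C(C)C)C[C@@H](C)[C@H](C)Nc1cc-3ccc1C(N)=O)CC(C)(C)CC2=O` keeps the shared core and alters one group, on a carbonyl carbon whose other neighbours are an amide-type nitrogen in a ring: 1-amino-2-methylpropyl in place of 2-methoxyethyl on a carbonyl carbon. In words, 1-amino-2-methylpropyl stands in place of 2-methoxyethyl.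

For the measured compounds named here, only one measured step bears on this change. It is a 1.1-fold higher number from compound 1 to compound 2 (0.04 log units; within the scatter), with (2-methoxyethyl)carbonyl in place of methyl on an amine nitrogen in a ring. That step touched the same nitrogen and stayed small, so no step beyond the scatter is expected in this assay. Going by the values given here, no measured compound carries an amino group in this chain, however, so the range has to stay wide.

The estimated change is a 1.1-fold higher number from compound 2 to compound 3 (0.03 log units; within the scatter). For compound 3 the expected value is 58 nM, with an estimated range from 22 nM to 150 nM.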

Compound 3, half-maximal inhibitory concentration: 48 nM
For compound 3 the middle estimate is 1.2-fold (0.08 log units) above the measured one, and the stated range covers the measured number.
By their numbers in this assay, from the lowest: compounds 3, 1 and 2 (each within the scatter of the next).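

In this assay, replacing 2-methoxyethyl with 1-amino-2-methylpropyl on the carbonyl carbon gives a 1.1-fold lower number from compound 2 to compound 3 (0.05 log units; within the scatter), and the wider change from the methyl on the ring nitrogen gives a 1.0-fold lower number from compound 1 to compound 3 (0.01 log units; within the scatter). The entering chain brings an amino group, with a hydrogen-bond donor and a defined stereocentre, yet all three compounds remain within the scatter of one another, so a methyl, a (2-methoxyethyl)carbonyl and a (1-amino-2-methylpropyl)carbonyl on this nitrogen in a ring cannot be told apart on these numbers. No measurement shown here offers an explanation for this result.

The compounds shown leave open whether the opposite arrangement at the new stereocentre would give a similar number, and whether a carboxylic acid in place of the amino group, a longer chain or a plain hydrogen on the nitrogen would also stay within the scatter. They also leave open whether this tolerance for different groups holds for changes made elsewhere on the shared core.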